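Propyl removal across two cores; outlook for compound 4

A few compounds are considered here, and "the series" means these few. Any claim that something is new, unique, unknown or untested is made for them only; others in the source may bear on it.

All values below are from a functional assay for inhibition, with Homo sapiens as the target; a higher number here means a weaker inhibitor, a lower number a stronger inhibitor.

Compound 1, `CCCc1nc(C)c2ccnc(Nc3cc[nH]n3)n12`: compound 1 gives 25000 nM.
Compound 2, `CCCc1cnc(Nc2cc[nH]n2)n2c(CCC)nc(C)c12`: for compound 2 the result > 48000 nM is a limit of the assay, not a number.
Compound 3, `C=CCn1ncc2c(CCC)ncn2c1=O`: for compound 3 the result > 48000 nM is a limit of the assay, not a number.

Two of the three values sit at the limit of > 48000 nM in this assay, at which 2 of the 3 values shown sit. Within the data shown here, the one counted step is hydrogen in place of propyl on an aromatic carbon, giving an at least 1.9-fold lower number from compound 2 to compound 1 (0.28 log units; that floor lies within the scatter). Since the value of compound 2 is a limit, the real size of this step is not fixed. How the core of compound 3 differs from the core of compound 2 is not broken down here.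

Compound 4, `C=CCn1ncc2cncn2c1=O`, has not yet been measured in this assay. It relates to compound 3 by hydrogen in place of propyl on an aromatic carbon. This is the same kind of change as from compound 2 to compound 1, but not the same: there the propyl sat on a six-membered aromatic ring with 2 nitrogen, ortho to a fused ring and para to a (1H-pyrazol-3-yl)amino group; here it sits on a five-membered aromatic ring with 2 nitrogen, next to the ring nitrogen. Among the measured compounds shown here, the only comparable step rests on a limit and lies within the scatter, and compound 3 itself is a limit, so little can be carried over. From compound 3 to compound 4 a step that the limit leaves unreadable from compound 3 to compound 4 is expected, amounting to no clear change. Compound 4 is estimated at 60000 nM, with a likely range from 20000 nM to 150000 nM, and a limit is the more probable outcome.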

Compound 4, half-maximal inhibitory concentration: > 48000 nM
Compound 4: no number, only a limit (the forecaster's own chance of this, stated with the estimate: 70%); the middle value lies beyond the limit too.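

In this assay compound 4 gives > 48000 nM, which is a limit of the assay and not a number. Among these compounds, compound 3 also stands at a limit, so no step between compound 3 and compound 4 can be read. The series now mostly sits at one boundary: the limit of > 48000 nM in this assay, at which 3 of the 4 values shown sit. On these data alone, it remains open whether hydrogen in place of propyl changes inhibition at all on the core of compound 3.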